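The compounds below may be only part of what the source reports. "The series", "measured", "known", "first", "only" and "open" are said of these compounds alone.

In a functional assay on HCT-116 cells (Homo sapiens) for antiproliferative activity, read by MTT assay, with a stated time of 48 h (on this read-out lower numbers stand for stronger inhibition and higher numbers for weaker inhibition), compound 1 `COc1ccc(-c2c(Nc3ccc(C)cc3)c3ccccc3oc2=O)cc1` gives 64800 nM, and compound 2 `COc1ccc(-c2c(Nc3cccc(C(F)(F)F)c3)c3ccccc3oc2=O)cc1` gives 55700 nM. These two numbers lie within the usual scatter of each other, so compound 1 cannot be ranked against compound 2, and both sit together as the only measured reference points. Compound 3 `COc1ccc(-c2c(Nc3ccc(C)cc3)c3ccc(OC)cc3oc2=O)cc1` keeps the core of compound 1 and carries one change, methoxy in place of hydrogen on an aromatic carbon. The new group sits on a six-membered aromatic ring of carbon only, part of a fused or bridged system of two rings. Among the compounds with values here, the sole measured step, a 1.2-fold lower number from compound 1 to compound 2 (0.07 log units; within the scatter), instead exchanges 4-methylphenyl for 3-(trifluoromethyl)phenyl on a nitrogen, so it speaks only indirectly to this change. Within the data shown here, no measured pair tests a methoxy group at this place. Among the measured compounds shown here, with that one small step as the only guide, no shift beyond the scatter is expected, and the estimate is a 1.2-fold lower number from compound 1 to compound 3 (0.07 log units; within the scatter). For compound 3 the estimated value is 55000 nM, with an expected range from 22000 nM to 130000 nM.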

Compound 3, half-maximal inhibitory concentration: 82400 nM
Estimate against measurement, compound 3: 1.5-fold (0.18 log units) below; the range from low to high includes it.
By their numbers in this assay, from the lowest: compounds 2, 1 and 3 (each within the scatter of the next).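

In this assay methoxy in place of hydrogen on this aromatic carbon, meta to a fused ring and para to a fused ring, gives a 1.3-fold higher number from compound 1 to compound 3 (0.10 log units; within the scatter) and so leaves the number inside the usual spread of repeat measurements. The earlier pair differs only in the group on the nitrogen, so this is the first sign in the compounds shown that the ring of the shared core can carry a group of this size, an added methoxy with its one hydrogen-bond acceptor, without a reading that stands apart from compound 1. No supporting data bear on this result, so the step can be reported but not explained.

Going by these compounds, whether an amine, a carboxylic acid or a longer chain such as butoxy on this same carbon would move the number beyond the scatter remains open. Also open, on these data alone, is whether methoxy here would behave the same way with 3-(trifluoromethyl)phenyl on the nitrogen in place of 4-methylphenyl, a combination that would need its own reading.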